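Swapping Two Ester Groups on a Chain Near the Ring

A few compounds are considered here, and "the series" means these few. Any claim that something is new, unique, unknown or untested is made for them only; others in the source may bear on it.

Compound 1 `C#Cc1cccc(NC(=O)c2cn(CC(=O)OCC)nn2)c1` is an anilide carrying a triazole whose nitrogen bears a short chain ending in an ester. In a functional assay on B16 cells (Mus musculus) for cytotoxicity, read by MTT assay, with a stated time of 48 h (a higher number here means a weaker inhibitor, a lower number a stronger inhibitor), compound 1 gives 91000 nM. Compound 2 `C#Cc1cccc(NC(=O)c2cn(CCOC(C)=O)nn2)c1` keeps everything except that chain end, where the change acetoxymethyl in place of ethoxycarbonyl on a saturated chain carbon bound to an aromatic nitrogen is made. In this assay compound 2 gives 25100 nM, so the step of a 3.6-fold lower number from compound 1 to compound 2 (0.56 log units; beyond the scatter) makes compound 2 the stronger of the two.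

Compound 3 `CCOC(=O)Cn1cc(CNC(=O)c2cn(Cc3ccccc3)nn2)nn1` has a different core from compound 1; the difference between the two cores is not broken down here. In this assay compound 3 gives 35000 nM. Compound 4 `CC(=O)OCCn1cc(CNC(=O)c2cn(Cc3ccccc3)nn2)nn1` is compound 3 with the change (acetoxymethyl in place of ethoxycarbonyl on a saturated chain carbon bound to an aromatic nitrogen), the same change as from compound 1 to compound 2, at the same kind of place.

Because compound 1 moving to compound 2 showed a 3.6-fold lower number from compound 1 to compound 2 (0.56 log units; beyond the scatter), a step of similar size is expected for compound 4, a 2.9-fold lower number from compound 3 to compound 4 (0.46 log units; beyond the scatter), though this rests on a single earlier pair on a different core. Compound 4 is therefore estimated at 12000 nM, between 4000 nM and 40000 nM.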

Compound 4, half-maximal inhibitory concentration: 28000 nM
Compound 4: the middle estimate sits 2.3-fold (0.37 log units) below what was measured; low and high end bracket the measured number.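

On the core of compound 3, the same swap of ethoxycarbonyl for acetoxymethyl gives a 1.3-fold lower number from compound 3 to compound 4 (0.10 log units; within the scatter), so in this assay the two ester chains cannot be told apart on this core. The change therefore does not carry over at the same size, and the two steps differ by more than repeat measurements would be expected to explain: the same change on two cores in this assay, a 3.6-fold lower number (0.56 log units; beyond the scatter) from compound 1 to compound 2 and a 1.3-fold lower number (0.10 log units; within the scatter) from compound 3 to compound 4, 2.9-fold (0.46 log units) apart, beyond the scatter of two such steps This shows that a gain seen on one core in this series need not appear on another, but two pairs cannot show which feature of the cores sets the gap, or how the swap would behave on a third core.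

The compounds shown leave open whether the end of this chain matters at all on the core of compound 3 once the ester is replaced by something quite different, such as a carboxylic acid or an amine. They also leave open what a free alcohol or a longer chain at the same place would do on either core.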